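Series notes: ethynyl for ethyl on the shared core

The compounds below may be only part of what the source reports. "The series", "measured", "known", "first", "only" and "open" are said of these compounds alone.

Compound 1 `Cc1ccc(CCc2cc3cn([C@H]4C[C@H](O)[C@@H](CO)O4)c(=O)nc3o2)cc1` is the reference point of the set. Among the compounds with values here, in an ADME assay on HEL cells (Homo sapiens) for cytotoxicity, with a stated time of 3 days (a higher number here means that more compound is tolerated, a lower number that less compound is tolerated), compound 1 gives 540000 nM, the only plain number among the three values. Compound 2 `CCCCCc1ccc(CCc2cc3cn([C@H]4C[C@H](O)[C@@H](CO)O4)c(=O)nc3o2)cc1` carries butyl in place of hydrogen on a saturated chain carbon bound to an aromatic carbon. In this assay compound 2 returns only a limit, >= 470000 nM. The step that the limit leaves unreadable from compound 1 to compound 2 is therefore not readable. Compound 3 `CCCCCCc1cnc(-c2cc3cn([C@H]4C[C@H](O)[C@@H](CO)O4)c(=O)nc3o2)nc1` likewise returns only a limit in this assay, namely > 100000 nM.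

The unmeasured compound 4 `Cc1ccc(C#Cc2cc3cn([C@H]4C[C@H](O)[C@@H](CO)O4)c(=O)nc3o2)cc1` differs from compound 1 by 2-(4-methylphenyl)ethynyl in place of 2-(4-methylphenyl)ethyl on an aromatic carbon. Within the data shown here, no measured step bears directly on this change; the single step in the set, a step that the limit leaves unreadable from compound 1 to compound 2, concerns the saturated chain carbon bound to an aromatic carbon and is unreadable. Across compound 1, compound 2 and compound 3 the minimum cytotoxic concentration stays high throughout, so for compound 4 no step beyond the scatter is expected in this assay, in either direction. Compound 4 is therefore expected to give about 400000 nM, with a range of 100000 nM to 1000000 nM. The expected step is a 1.4-fold lower number from compound 1 to compound 4 (0.13 log units; within the scatter), which amounts to essentially no change.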

Compound 4, minimum cytotoxic concentration: >= 510000 nM
Compound 4 gave a limit, no number; the forecaster's own chance of this, stated with the estimate: 50%; middle value at least 1.2-fold (0.10 log units) from the limit.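

In this assay compound 4 returns only a limit, >= 510000 nM. The step from compound 1 to compound 4 therefore cannot be read. The compounds shown leave open whether 2-(4-methylphenyl)ethynyl in place of 2-(4-methylphenyl)ethyl on the shared core changes the minimum cytotoxic concentration at all, and, if it does, in which direction and how far.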